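Trifluoromethyl to Methyl on Two Related Amide Cores

The source may hold more compounds than are shown below. What is called first, only, known or untested is meant among the compounds shown, and "the series" means these compounds.

Compound 1 `NC(=O)c1c(NC(=O)c2ccc(C(F)(F)F)cc2)sc2c1CCN(Cc1ccc(Cl)cc1Cl)C2` and compound 2 `Cc1ccc(C(=O)Nc2sc3c(c2C(N)=O)CCN(Cc2ccc(Cl)cc2Cl)C3)cc1` share one core, while compound 3 `NC(=O)c1c(NC(=O)c2ccccc2C(F)(F)F)sc2c1CCN(C(=S)Nc1ccccc1Cl)C2` and compound 4 `Cc1ccccc1C(=O)Nc1sc2c(c1C(N)=O)CCN(C(=S)Nc1ccccc1Cl)C2` share another; the difference between the two cores is not broken down here. In a functional assay on HL-60 cells (Homo sapiens) for antiproliferative activity, with a stated time of 24 h (a lower number here means a stronger inhibitor, a higher number a weaker inhibitor), compound 1 gives 14900 nM. Compound 2, which carries the change (methyl in place of trifluoromethyl on an aromatic carbon), gives 19900 nM in this assay, so the step is a 1.3-fold higher number from compound 1 to compound 2 (0.13 log units; within the scatter). Compound 3 gives 17600 nM in this assay; its value sits close to those of compound 1 and compound 2, and none of the three stands apart from the others.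

Compound 4 has not yet been measured. It differs from compound 3 by methyl in place of trifluoromethyl on an aromatic carbon. This is the same kind of change as that from compound 1 to compound 2, but not the same: in the measured pair the group sits para to a large group, whereas in compound 4 it sits ortho to a large group. Going by the values given here, only one measured example of this kind of change exists, and it is small. Resting on the step of a 1.3-fold higher number from compound 1 to compound 2 (0.13 log units; within the scatter), the expected step in this assay is a 1.2-fold higher number from compound 3 to compound 4 (0.08 log units; within the scatter). From the compounds shown here alone, compound 4 is therefore estimated at 21000 nM in this assay, with a likely range from 9000 nM to 50000 nM; the ortho placement is untested, so the range is kept wide.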

Compound 4, half-maximal inhibitory concentration: 20900 nM
Beside the measured number, compound 4's estimate is 1.0-fold (0.00 log units) above it; measured number inside the range.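

On the core of compound 3, going from 2-(trifluoromethyl)phenyl to 2-methylphenyl gives a 1.2-fold higher number from compound 3 to compound 4 (0.07 log units; within the scatter) in this assay, so the number does not shift by more than the usual scatter. Set beside the earlier step, the change carries from one core to the other with no difference that can be told apart: the same change on two cores in this assay, a 1.3-fold higher number (0.13 log units; within the scatter) from compound 1 to compound 2 and a 1.2-fold higher number (0.07 log units; within the scatter) from compound 3 to compound 4, 1.1-fold (0.05 log units) apart, within the scatter of two such steps. Neither step stands beyond the scatter, so the two pairs show only that swapping trifluoromethyl for methyl leaves the number unmoved on both cores; they do not show a real effect being transferred, and two pairs cannot speak for other cores or for any other assay.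

The compounds shown leave open whether a different group in this place on the aromatic ring, such as a nitrile, a methoxy group or an amine, would move the number beyond the scatter on either core. They also leave open what happens when the carboxamide on the shared part of the two cores gives way to a carboxylic acid or a nitrile, and whether such a change would behave alike on both cores.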